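One added chloro on compound 1

This account rests on a few compounds, and the source may have more. Where it says the series, first, only, none or still open, it means among the compounds named here.

Compound 1 `O=[N+]([O-])c1cc(C(F)(F)F)cc([N+](=O)[O-])c1Oc1ccc(Cl)cc1/C=N\OCc1ccccc1F`: 1020 nM
Compound 2 `O=[N+]([O-])c1cc(C(F)(F)F)cc([N+](=O)[O-])c1Oc1ccc(Cl)cc1/C=N\OCc1ccc(Cl)cc1Cl`: 1280 nM

In a functional assay on HepG2 cells (Homo sapiens) for antiproliferative activity, read by MTT assay, with a stated time of 48 h (on this read-out higher numbers stand for weaker inhibition and lower numbers for stronger inhibition), compound 1 gives 1020 nM. Among the measured compounds shown here, its only measured neighbour is compound 2, and the two values lie within the scatter of each other. The unmeasured compound 3 `O=[N+]([O-])c1cc(C(F)(F)F)cc([N+](=O)[O-])c1Oc1c(Cl)cc(Cl)cc1/C=N\OCc1ccccc1F` differs from compound 1 by a single change, chloro in place of hydrogen on an aromatic carbon. For the measured compounds named here, only one measured step is available, a 1.3-fold higher number from compound 1 to compound 2 (0.10 log units; within the scatter). That step swaps 2-fluorophenyl for 2,4-dichlorophenyl, elsewhere in the molecule, so it bears on the new change only indirectly. Going by the values given here, no measurement yet covers a change at the place of the new chloro. No step beyond the scatter is therefore expected in this assay, in either direction. The estimated step is a 1.0-fold lower number from compound 1 to compound 3 (0.01 log units; within the scatter). For compound 3 the expected value is 1000 nM, with an estimated range from 450 nM to 2200 nM.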

Compound 3, half-maximal inhibitory concentration: 820 nM
Compound 3: middle estimate off by 1.2-fold (0.09 log units), on the high side, within the range that was stated.
By their numbers in this assay, from the lowest: compounds 3, 1 and 2 (each within the scatter of the next).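

In this assay, the change of chloro in place of hydrogen on an aromatic carbon, ortho to a large group, gives a 1.2-fold lower number from compound 1 to compound 3 (0.09 log units; within the scatter). Among the compounds shown here, this is the first measurement at this position, and it shows that a chloro group can stand there, in a ring that already carries a chloro group meta to it, without a step beyond the scatter. No available evidence bears on this result.

One chloro group says little about how other groups would behave at this position, and an amine, a methoxy group or a carboxylic acid there could give a different result. From the compounds shown here alone, it also remains open whether the new chloro group would leave the value equally unchanged when paired with the side chain of compound 2.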